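The compounds below may be only part of what the source reports. "The series", "measured", "known", "first", "only" and "open" are said of these compounds alone.

Measured in a functional assay on LNCaP cells (Homo sapiens) for antiproliferative activity, read by MTT assay, with a stated time of 96 h; a lower number here means a stronger inhibitor, a higher number a weaker inhibitor:
compound 1 `FC(F)(F)Oc1cccc(Nc2nnnc3ccc(N4CCNCC4)nc23)c1`: 8510 nM
compound 2 `CCN1CCN(c2ccc3nnnc(Nc4cccc(OC(F)(F)F)c4)c3n2)CC1`: 14300 nM

In this assay compound 2 gives 14300 nM, which lies within the scatter of compound 1 at 8510 nM. The next compound, compound 3 `FC(F)(F)Oc1cccc(Nc2nnnc3ccc(N4CCCC4)nc23)c1`, has pyrrolidin-1-yl in place of 4-ethylpiperazin-1-yl on an aromatic carbon. Among the compounds with values here, only one measured step bears on this change, a 1.7-fold higher number from compound 1 to compound 2 (0.23 log units; within the scatter), with ethyl in place of hydrogen on an amine nitrogen in a ring. Within the data shown here, that step stays within the scatter, but it leaves the ring itself untouched, and no measured step exchanges that ring. The data therefore give no firm direction, and no shift beyond the scatter is expected in this assay. The expected change is a 1.4-fold lower number from compound 2 to compound 3 (0.16 log units; within the scatter), which is small and uncertain. For compound 3 the estimated value is 10000 nM, with an expected range of 3500 nM to 30000 nM.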

Compound 3, half-maximal inhibitory concentration: > 100000 nM
Compound 3: no number, only a limit (the forecaster's own chance of this, stated with the estimate: 10%); middle value at least 10-fold (1.00 log units) away from the limit.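

Within the data shown here, exchanging the ring itself, which the earlier compounds left untouched, is the first change at this position to go beyond the scatter. On this aromatic carbon, pyrrolidin-1-yl in place of 4-ethylpiperazin-1-yl gives an at least 6.9-fold higher number from compound 2 to compound 3 (0.84 log units; beyond the scatter), and pyrrolidin-1-yl in place of piperazin-1-yl gives an at least 11-fold higher number from compound 1 to compound 3 (1.07 log units; beyond the scatter), whereas the ethyl on the ring nitrogen gave only a 1.7-fold higher number from compound 1 to compound 2 (0.23 log units; within the scatter), within the scatter. Compound 3 gives no number in this assay, only a limit, so these steps mark the smallest possible size of the change: the limit of > 100000 nM in this assay, at which 1 of the 3 values shown sits.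

The compounds shown leave open whether this change follows the smaller ring or the loss of the second ring nitrogen. On these data alone, a piperidin-1-yl or morpholin-4-yl group at the same carbon would separate the two, and how far compound 3 lies past its limit also remains unknown.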